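Nitrobenzylidene Imine in Place of the Oxamate Side Chain

The compounds below may be only part of what the source reports. "The series", "measured", "known", "first", "only" and "open" are said of these compounds alone.

Compound 1 `N#CC1=C(/N=C/Nc2ccc([N+](=O)[O-])cc2)N(c2ccccc2)C(=O)N2CCCCC(N3CCCC3)C12`: 85.6%
Compound 2 `COc1ccc(N/C=N/C2=C(C#N)C3C(N4CCCC4)CCCCN3C(=O)N2c2ccccc2)cc1`: 50.2%
Compound 3 `CCOC(=O)C(=O)NC1=C(C#N)C2C(N3CCCC3)CCCCN2C(=O)N1c1ccccc1`: 91.5%

In a functional assay on the whole organism (strain albino) for inhibition, with Rattus norvegicus as the target, read by paw edema, with stated times of 1 h and 3 h, at a dose of 20 mmol/kg by the intraperitoneal route (on this read-out lower numbers stand for a weaker effect and higher numbers for a stronger effect at the one dose given), compound 3 gives 91.5%, the highest of the three numbers, though the step of a number 5.9 percentage points higher from compound 1 to compound 3 (within the scatter) is within the scatter, while the step of a number 41.3 percentage points higher from compound 2 to compound 3 (beyond the scatter) is large. Compound 4 `N#CC1=C(/N=C/c2ccc([N+](=O)[O-])cc2)N(c2ccccc2)C(=O)N2CCCCC(N3CCCC3)C12` differs from compound 3 by a group of 11 heavy atoms (7 carbon, 2 nitrogen, 2 oxygen; one six-membered aromatic ring of carbon only) in place of a group of 8 heavy atoms (4 carbon, 1 nitrogen, 3 oxygen; no ring), on a double-bonded ring carbon. The entering group carries the nitro seen in compound 1 and lacks the methoxy of compound 2, so the steps of a number 5.9 percentage points higher from compound 1 to compound 3 (within the scatter) and a number 41.3 percentage points higher from compound 2 to compound 3 (beyond the scatter) bear on it: the first small, the second large only where methoxy replaced nitro. A small downward step at most is therefore expected. Compound 4 is estimated at 82%, in the range 58% to 95%, an expected step of a number 9.5 percentage points lower from compound 3 to compound 4 (within the scatter) within the scatter.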

Compound 4, a percentage reported as inhibition, in the whole organism at one dose (the size of the read-out at that dose, not a potency): 91.7%
Estimate against measurement, compound 4: 9.7 percentage points below; the measured number falls inside the stated range.
By their numbers in this assay, from the lowest: compound 2; then compounds 1, 3 and 4 (each within the scatter of the next).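

At the double-bonded ring carbon, the two groups in compound 3 and compound 4 cannot be told apart in this assay, with a number 0.2 percentage points higher from compound 3 to compound 4 (within the scatter), so this read-out tolerates a ring-bearing imine as well as ((ethoxycarbonyl)carbonyl)amino. On the carbon with a double bond to nitrogen, the amino link makes no readable difference with the nitro kept, a number 6.1 percentage points higher from compound 1 to compound 4 (within the scatter), whereas a number 41.5 percentage points higher from compound 2 to compound 4 (beyond the scatter) changes both the link and the ring substituent. Nothing measured here accounts for these steps. Going by these compounds, it remains open whether 4-methoxyphenyl without the amino link would stand with compound 2 or compound 4, and whether an amine or a carboxylic acid in place of the nitro would keep the number.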